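The compounds below may be only part of what the source reports. "The series", "measured", "known", "first", "only" and "open" are said of these compounds alone.

Compound 1 `CCCC(O)CC(=O)O[C@H](CC=C(C)C)C1=CC(=O)c2c(O)ccc(O)c2C1=O`: 59300 nM
Compound 2 `COC(C)CO[C@H](CC=C(C)C)C1=CC(=O)c2c(O)ccc(O)c2C1=O`: 53400 nM
Compound 3 `COCCO[C@H](CC=C(C)C)C1=CC(=O)c2c(O)ccc(O)c2C1=O`: 62400 nM

All three were measured in a functional assay on HeLa cells (Homo sapiens) for cytotoxicity, read by MTT assay; a lower number here means a stronger inhibitor, a higher number a weaker inhibitor. Compound 1 stands second highest of the three numbers, but the two steps that separate it from its neighbours, a 1.1-fold higher number from compound 1 to compound 3 (0.02 log units; within the scatter) and a 1.1-fold lower number from compound 1 to compound 2 (0.05 log units; within the scatter), are both within the scatter, so the three compounds cannot be told apart on this assay.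

Compound 4 `CC(C)=CC[C@@H](OC(=O)CC(O)c1ccccc1)C1=CC(=O)c2c(O)ccc(O)c2C1=O` is the next compound to be measured. It differs from compound 1 in one place:

phenyl in place of propyl on a saturated chain carbon bound to an oxygen on a saturated carbon and a saturated chain carbon

The shared core and the group on the oxygen on a saturated carbon are kept; only the end of the side chain changes. Going by the values given here, none of the measured steps exchanges a propyl for a phenyl. The closest comparison is a 1.2-fold higher number from compound 2 to compound 3 (0.07 log units; within the scatter), which swaps a hydrogen for a methyl at the same kind of place and lies within the scatter, and the two larger rearrangements of that chain in the steps from compound 1 also stayed within the scatter. With nothing pointing in either direction, the expectation for compound 4 is a 1.1-fold lower number from compound 1 to compound 4 (0.03 log units; within the scatter), a change no larger than the scatter. The estimate for compound 4 in this assay is therefore 55000 nM, with a range from 20000 nM to 150000 nM.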

Compound 4, half-maximal inhibitory concentration: 44500 nM
Compound 4: the middle estimate sits 1.2-fold (0.09 log units) above what was measured; measured number inside the range.
By their numbers in this assay, from the lowest: compounds 4, 2, 1 and 3 (each within the scatter of the next).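

In this assay, putting a phenyl in place of propyl on this saturated chain carbon gives a 1.3-fold lower number from compound 1 to compound 4 (0.12 log units; within the scatter), so compound 1 and compound 4 cannot be told apart. Going by these compounds alone, this is the first look at a ring at this place: a six-membered aromatic ring of carbon only, with 6 heavy atoms where the propyl has 3, and the larger ring-bearing end of the chain leaves the reading of this cytotoxicity test within the usual variation. The earlier compounds shown here varied the chain in other ways and could not show that a propyl and a phenyl at this place read alike. No measurement here offers an explanation for this result.

From the compounds shown here alone, whether an amine, a carboxylic acid, a chain longer than propyl or a phenyl carrying a further group such as methoxy at this place would give a step beyond the scatter remains open. Going by these compounds, the shared core is the same in all four compounds, so what a change there would do also remains open.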